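From a Urea Limit to a Cyclobutyl Amide

This account rests on a few compounds, and the source may have more. Where it says the series, first, only, none or still open, it means among the compounds named here.

Measured compounds:
compound 1, `O=C(c1ccc(F)c(F)c1)N1CC(c2nc(-c3cccc(F)c3)no2)C1`: 3200 nM
compound 2, `COC1CCCN(C(=O)N2CC(c3nc(-c4cccc(Cl)c4)no3)C2)C1`: > 10000 nM
compound 3, `O=C(c1ccc(Cl)cc1)N1CC(c2nc(-c3cccc(F)c3)no2)C1`: 2500 nM

Of the compounds shown here, three sharing one core have been tested in an assay on HEK293 cells for positive allosteric modulation of metabotropic glutamate receptor 5 (Homo sapiens), read by FLIPR; on this read-out lower numbers stand for an effect already at smaller amounts and higher numbers for an effect only at larger amounts of compound. Compound 1 gives 3200 nM, and compound 3 gives 2500 nM; the step of a 1.3-fold lower number from compound 1 to compound 3 (0.11 log units; within the scatter) is within the scatter. Compound 2 stands apart: it reaches only a limit of the assay, > 10000 nM, so no number is known for it. (the limit of > 10000 nM in this assay, at which 1 of the 3 values shown sits).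

Compound 4 `O=C(C1CCC1)N1CC(c2nc(-c3cccc(Cl)c3)no2)C1` differs from compound 2 in one place: cyclobutyl in place of 3-methoxypiperidin-1-yl on a carbonyl carbon. Among the compounds with values here, no measured step covers this change; the one measured step, between compound 1 and compound 3, exchanges one aryl group for another on the carbonyl carbon and was within the scatter. What the data do show is that the two carbonyl compounds with a ring carbon on the carbonyl, compound 1 and compound 3, give numbers, while the urea, compound 2, gives only a limit. The step to compound 4 is therefore expected to be an at least 2.8-fold lower number from compound 2 to compound 4 (0.45 log units; beyond the scatter), towards smaller amounts. Compound 4 is estimated at 3500 nM, with a range from 900 nM to 12000 nM.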

Compound 4, half-maximal effective concentration: > 10000 nM
Compound 4: no number, only a limit (the forecaster's own chance of this, stated with the estimate: 30%); middle value at least 2.8-fold (0.45 log units) from the limit.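

In this assay compound 4 gives > 10000 nM, a limit and not a number. Within the data shown here, compound 2 also sits at a limit, so no step from compound 2 to compound 4 can be read. The compounds shown leave open whether cyclobutyl or 3-methoxypiperidin-1-yl on a carbonyl carbon gives the lower number.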